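Pyridin-3-yl for 3-bromophenyl on the benzyl carbon

The source may report more compounds than this note shows. Statements on the series, on what has been measured and on what is new or still open speak of the compounds shown alone.

The series is followed in a functional assay on HL-60 cells (Homo sapiens), read by calcium flux; on this read-out lower numbers stand for an effect already at smaller amounts and higher numbers for an effect only at larger amounts of compound. Compound 1 `COc1cccc(Cc2cc(-c3cccs3)nn(CC(=O)Nc3ccc(F)cc3)c2=O)c1` gives > 50000 nM in this assay, which is a limit of the assay and not a number. Compound 2 `COc1cccc(Cc2cc(-c3ccc(C)cc3)nn(CC(=O)Nc3ccc(F)cc3)c2=O)c1` gives > 50000 nM in this assay, again a limit. The step that the two limits leave unreadable from compound 1 to compound 2 is therefore unreadable. Compound 3 `Cc1cc(Cc2cccc(Br)c2)c(=O)n(CC(=O)Nc2ccc(Br)cc2)n1` gives > 50000 nM in this assay, likewise a limit. All three values sit at the limit of > 50000 nM in this assay, at which 3 of the 3 values shown sit, so compound 3 cannot be placed against compound 1 or compound 2 within this assay; none of the three shows an effect within the measured range.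

Compound 4 `Cc1cc(Cc2cccnc2)c(=O)n(CC(=O)Nc2ccc(Br)cc2)n1` differs from compound 3 in one place: pyridin-3-yl in place of 3-bromophenyl on a saturated chain carbon bound to an aromatic carbon. Within the data shown here, no measured step touches this change, and the only step that exists in the set is the unreadable one a step that the two limits leave unreadable from compound 1 to compound 2. Nothing in the set shows that any change to this part of the molecule, or elsewhere, moves a compound off the limit. The expected step that the limit leaves unreadable from compound 3 to compound 4 is accordingly none beyond the scatter. Compound 4 is expected to give about 60000 nM in this assay, within 20000 nM to 200000 nM, and most probably to be reported as a limit once more.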

Compound 4, half-maximal effective concentration: > 50000 nM
Compound 4 gave a limit, no number; the forecaster's own chance of this, stated with the estimate: 85%; the middle value lies beyond the limit too.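

Compound 4, like compound 3, gives only a limit in this assay, so no step can be read between them, and pyridin-3-yl in place of 3-bromophenyl has no readable size: the limit of > 50000 nM in this assay, at which 4 of the 4 values shown sit.

For this assay, the compounds shown leave open which change to the shared core, if any, brings a value inside the measured range.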